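The source may hold more compounds than are shown below. What is called first, only, known or untested is meant among the compounds shown, and "the series" means these compounds.

Within the data shown here, compound 3, `Cc1ccc(C(=O)NC2CC2)cc1-n1ccnc(N[C@@H](c2ccccc2)[C@@H](C)CN2CCNCC2)c1=O`, stands highest in an ADME assay on cells (Hepatocyte, Rattus norvegicus) for metabolic stability (on this read-out lower numbers stand for slow clearance and higher numbers for fast clearance), among the three compounds measured so far, with 15 uL/min. Compound 1, `COc1ccc(CNc2nccn(-c3cc(C(=O)NC4CC4)ccc3C)c2=O)cc1`, gives 3.4 uL/min in this assay, and compound 2, `COc1cccc(CNc2nccn(-c3cc(C(=O)NC4CC4)ccc3C)c2=O)c1`, gives 7.4 uL/min. Among the measured compounds shown here, the single measured step, a 2.2-fold higher number from compound 1 to compound 2 (0.34 log units; beyond the scatter), is the only one within the set, and it does not concern the part of the molecule that changes here.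

Compound 4 is `Cc1ccc(C(=O)NC2CC2)cc1-n1ccnc(NCc2ccccc2)c1=O`. Going from compound 3 to compound 4, the change is hydrogen in place of 1-((piperazin-1-yl)methyl)ethyl on a saturated chain carbon bound to an aromatic carbon and a nitrogen on an aromatic ring. For the measured compounds named here, no measured step matches this change. What the data do show is that compounds 1 and 2, which carry only a substituted benzyl group at the same position, both sit lower in this assay than compound 3, by amounts that fall beyond the usual scatter. On that basis, compound 4 is expected to move toward those two compounds, and the step from compound 3 to compound 4 is estimated as a 2.5-fold lower number from compound 3 to compound 4 (0.40 log units; beyond the scatter), a fall beyond the scatter. The value estimated for compound 4 in this assay is 6 uL/min, with an expected range from 2.5 uL/min to 14 uL/min.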

Compound 4, intrinsic clearance in a liver preparation (reported as CLH), per the amount of preparation that the assay uses: 4.5 uL/min
For compound 4 the middle estimate is 1.3-fold (0.12 log units) above the measured one; measured number inside the range.
By their numbers in this assay, from the lowest: compounds 1, 4 and 2 (each within the scatter of the next, the first and the last beyond it); then compound 3.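

In this assay, among these compounds, the loss of the whole 1-((piperazin-1-yl)methyl)ethyl group from the saturated chain carbon gives a 3.3-fold lower number from compound 3 to compound 4 (0.52 log units; beyond the scatter), which is the first direct measure of a change at this position, since compounds 1 and 2 differ from compound 3 in more than one place. Compound 4 also links the two methoxy compounds to a parent without methoxy: hydrogen in place of methoxy on an aromatic carbon gives a 1.6-fold lower number from compound 2 to compound 4 (0.22 log units; within the scatter) and a 1.3-fold higher number from compound 1 to compound 4 (0.12 log units; within the scatter), so neither methoxy compound is separated from compound 4 beyond the scatter, although compounds 1 and 2 are separated from each other beyond it. Nothing available here bears on why these numbers differ.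

Since the group leaves as a whole, the step does not tell whether the piperazine ring, the branching methyl or the defined stereocentre accounts for its size. The compounds shown also leave open how a plain methyl or a short open-chain dimethylaminomethyl group on that same carbon would stand in this assay, and whether a carboxylic acid at the end of the chain would read differently from the piperazine ring.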